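Methylating the Side-Chain Hydroxy Group of Compound 1

The compounds below may be only part of what the source reports. "The series", "measured", "known", "first", "only" and "open" are said of these compounds alone.

Compound 1 `CCC(O)CO[C@H](CC=C(C)C)C1=CC(=O)c2c(O)ccc(O)c2C1=O` carries a 2-hydroxybutyl group on the oxygen of its side chain. In a functional assay on HeLa cells (Homo sapiens) for cytotoxicity, read by MTT assay (a lower number here means a stronger inhibitor, a higher number a weaker inhibitor), compound 1 gives 28700 nM, the lowest of the two values that came back as numbers. Compound 3 `CC(C)=CC[C@@H](OC(=O)CC(C)(O)c1ccccc1)C1=CC(=O)c2c(O)ccc(O)c2C1=O` has a different side chain on the same core; in this assay compound 3 gives 85700 nM, a higher number than compound 1, beyond the scatter. Compound 2 `CCCCCCC(C)(O)CC(=O)O[C@H](CC=C(C)C)C1=CC(=O)c2c(O)ccc(O)c2C1=O` reaches only a limit of this assay and no number, > 100000 nM (the limit of > 100000 nM in this assay, at which 1 of the 3 values shown sits). Going by the values given here, the single step measured between two compounds, an at least 1.1-fold lower number from compound 2 to compound 3 (0.06 log units; that floor lies within the scatter), exchanges phenyl for hexyl on a saturated chain carbon and has a floor that lies within the scatter.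

Compound 4 `CCC(CO[C@H](CC=C(C)C)C1=CC(=O)c2c(O)ccc(O)c2C1=O)OC` differs from compound 1 in one place: methyl in place of hydrogen on an oxygen on a saturated carbon. Among the compounds with values here, none of the measured steps touches an oxygen on a saturated carbon in this way, so no measured step bears directly on the change. Within the data shown here, with the only measured step sitting at its floor within the scatter, compound 4 is expected to move no further than that, a step of a 1.0-fold higher number from compound 1 to compound 4 (0.02 log units; within the scatter), in no particular direction. Compound 4 is therefore estimated at 30000 nM in this assay, with a range from 12000 nM to 80000 nM.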

Compound 4, half-maximal inhibitory concentration: 63500 nM
Compound 4: the middle estimate sits 2.1-fold (0.33 log units) below what was measured, and the stated range covers the measured number.
By their numbers in this assay, from the lowest: compound 1; then compounds 4 and 3 (each within the scatter of the next). At a limit, above all of these: compound 2.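

In this assay, going by these compounds alone, the change from 2-hydroxybutyl to 2-methoxybutyl brings a 2.2-fold higher number from compound 1 to compound 4 (0.34 log units; beyond the scatter) and gives the only measured step at this oxygen on a saturated carbon. It shows that the hydrogen on this oxygen is not interchangeable with methyl in this series: a single added carbon moves the number beyond the scatter and upward, and the hydroxy form, compound 1, keeps the lowest number among the compounds shown. Nothing among the compounds shown explains why the number rises with this change.

One step with one group cannot show whether the number keeps rising as the group on this oxygen grows, so an ethyl group or a longer chain there remains an open case, as does an amine or a carboxylic acid in place of the hydroxy group on this saturated carbon. Going by these compounds, it also remains open whether methyl in place of hydrogen on the hydroxy groups of compound 2 or compound 3, whose side chains differ from that of compound 1, would raise the number in the same way.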